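The source may report more compounds than this note shows. Statements on the series, on what has been measured and on what is new or still open speak of the compounds shown alone.

Compound 1 `CC(C)N(c1nc2c(ncn2-c2ccccc2)c(=O)n1-c1ccccc1)C(C)C`: > 100000 nM
Compound 2 `CCCCCN(CCCCC)c1nc2c(ncn2-c2ccccc2)c(=O)n1-c1ccc(Cl)cc1`: > 100000 nM

Both compounds were tested in a functional assay on OVCAR-3 cells (Homo sapiens) for cytotoxicity, read by MTT assay, with a stated time of 72 h; on this read-out lower numbers stand for stronger inhibition and higher numbers for weaker inhibition. For compound 1 the value > 100000 nM is a limit of the assay, not a number. For compound 2 the value > 100000 nM is likewise a limit. Compound 2 thus stands at the limit of > 100000 nM in this assay, at which 2 of the 2 values shown sit. Compound 3 `CCCCNc1nc2c(ncn2-c2ccccc2)c(=O)n1-c1ccc(Cl)cc1` differs from compound 2 by butylamino in place of dipentylamino on an aromatic carbon. Among the measured compounds shown here, no step between measured compounds is available to gauge such a change. Compound 3 is expected to stay near the limit, the step being estimated as a number no higher from compound 2 to compound 3 (the limit leaves the size open). The estimate for compound 3 is 100000 nM, ranging from 20000 nM to 300000 nM.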

Compound 3, half-maximal inhibitory concentration: 94800 nM
The estimate for compound 3 lay 1.1-fold (0.02 log units) above the measured number; the measured number falls inside the stated range.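

In this assay, compound 3 is the first compound shown to give a number rather than a limit, 94800 nM. Butylamino in place of dipentylamino on this aromatic carbon gives an at least 1.0-fold lower number from compound 2 to compound 3 (0.02 log units; that floor lies within the scatter). On these data alone, only this floor can be read, so the true size of the step remains open, and the change shows no gain that stands clear of the scatter.

The compounds shown leave open whether a shorter chain such as ethylamino, a ring amine such as morpholine, or a carboxylic acid on this carbon would bring a lower number.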